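The compounds below may be only part of what the source reports. "The series", "measured", "known", "first", "only" and "open" are said of these compounds alone.

Notes on the series. In a functional assay on Jurkat cells (Homo sapiens) (a higher number here means a weaker inhibitor, a lower number a stronger inhibitor), compound 1 `CC(C)[C@H](NC(=O)COc1cccc2ccccc12)C(=O)N[C@@H](CC(=O)O)C(=O)COc1cc(F)cc(F)c1` gives > 100000 nM, which is a limit of the assay and not a number. Within the data shown here, compound 2 `CC(C)[C@H](NC(=O)COc1cccc2ccccc12)C(=O)N[C@@H](CC(=O)O)C(=O)COc1ccc(F)c(F)c1F` gives 35800 nM, the only true number so far.

Compound 3 `CC(C)[C@H](NC(=O)COc1cccc2ccccc12)C(=O)N[C@@H](CC(=O)O)C(=O)COc1cc(F)c(F)cc1F` keeps the core of compound 2 and changes only the aryl group: 2,4,5-trifluorophenyl in place of 2,3,4-trifluorophenyl on an oxygen on a saturated carbon. In words, 2,4,5-trifluorophenyl stands in place of 2,3,4-trifluorophenyl on an oxygen on a saturated carbon.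

Among the measured compounds shown here, one measured step bears on this, the change at the same place an at least 2.7-fold lower number from compound 1 to compound 2 (0.44 log units; beyond the scatter). One end of that step is a limit (the limit of > 100000 nM in this assay, at which 1 of the 2 values shown sits), so its full size is not known. It shows that changing this aryl group can move the number in this assay, but it gives no direction for a shift of fluorines between two trifluorophenyl groups. No step beyond the scatter is therefore expected, in either direction.

The estimated step is a 1.1-fold higher number from compound 2 to compound 3 (0.05 log units; within the scatter). For compound 3 the expected value is 40000 nM, with an estimated range of 12000 nM to 100000 nM.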

Compound 3, half-maximal inhibitory concentration: 39300 nM
Beside the measured number, compound 3's estimate is 1.0-fold (0.01 log units) above it; low and high end bracket the measured number.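

In this assay, the step between the two trifluorophenyl groups is a 1.1-fold higher number from compound 2 to compound 3 (0.04 log units; within the scatter), so on an oxygen on a saturated carbon, the 2,3,4-trifluorophenyl and 2,4,5-trifluorophenyl groups read alike. The 2,4,5-trifluorophenyl group also stands apart from the 3,5-difluorophenyl group, with an at least 2.5-fold lower number from compound 1 to compound 3 (0.40 log units; beyond the scatter), which means the lower number seen with compound 2 is not confined to a single arrangement of three fluorines. The value of compound 1 is a limit and not a number, so the full size of the steps that start from it stays unknown: the limit of > 100000 nM in this assay, at which 1 of the 3 values shown sits.

Still open, on these data alone, is whether the difference from compound 1 follows the third fluorine or the places the fluorines occupy, since the 3,5-difluorophenyl group differs from both trifluorophenyl groups in count and in arrangement, and a 2,4-difluorophenyl or a plain phenyl group at the same place would help to separate the two. Also open is whether a chlorine or a methoxy group on this aryl ring, or a sulfur in place of the oxygen, would move the number in this assay further than any fluorine pattern shown here.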